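The source may report more compounds than this note shows. Statements on the series, on what has been measured and on what is new or still open speak of the compounds shown alone.

- compound 1 `COc1cc2c(Oc3ccc(NC(=O)c4nn(-c5ccccc5C(F)(F)F)ccc4=O)cc3)ccnc2cc1OCC(=O)NO`: 6320 nM
- compound 2 `COc1cc2c(Oc3ccc(NC(=O)c4nn(-c5ccccc5C)cc(C)c4=O)cc3F)ccnc2cc1OCCCC(=O)NO`: 2600 nM

Of the compounds shown here, two have been measured in a functional assay on MCF7 cells (Homo sapiens) for inhibition, read by MTT assay, with a stated time of 72 h (on this read-out higher numbers stand for weaker inhibition and lower numbers for stronger inhibition), so far. Compound 2 gives 2600 nM, the lower of the two numbers and so the stronger inhibition of the pair. Compound 1 stands at 6320 nM, and the gap between the two lies beyond the usual scatter. Going by the values given here, these two compounds differ in more than one place, so no measured step isolates a single change.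

The next compound, compound 3 `COc1cc2c(Oc3ccc(NC(=O)c4nn(-c5ccccc5)cc(C)c4=O)cc3F)ccnc2cc1OCCCC(=O)NO`, departs from compound 2 at one spot: hydrogen in place of methyl on an aromatic carbon. In words, hydrogen stands in place of methyl on an aromatic carbon, turning 2-methylphenyl into phenyl. The expectation rests only on compound 2 at 2600 nM and on the small size of this change. In this assay no step beyond the scatter is expected, in either direction, and the estimated 1.1-fold lower number from compound 2 to compound 3 (0.03 log units; within the scatter) is correspondingly small. For compound 3 the estimate is 2400 nM with an expected range from 900 nM to 6500 nM.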

Compound 3, half-maximal inhibitory concentration: 1900 nM
Compound 3: middle estimate off by 1.3-fold (0.10 log units), on the high side; measured number inside the range.
By their numbers in this assay, from the lowest: compounds 3 and 2 (each within the scatter of the next); then compound 1.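

In this assay, replacing the methyl of the 2-methylphenyl group with hydrogen to leave phenyl gives a 1.4-fold lower number from compound 2 to compound 3 (0.14 log units; within the scatter), so this first comparison that isolates a single change finds no difference that can be read between the two compounds. The methyl sits on an aromatic carbon of a six-membered aromatic ring of carbon only, ortho to a large group, and on this read-out compound 3 keeps the inhibition of compound 2 without it, so the methyl is not needed to hold that level. Nothing available here bears on the reason for this result.

The compounds shown leave open whether this position accepts groups other than methyl and hydrogen, such as a chlorine atom, a methoxy group or an amine, and whether any of them would move the number beyond the scatter. They also leave open whether the same exchange of methyl for hydrogen would read the same way on a compound with a different chain, such as a carboxylic acid in place of the hydroxamic acid end.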